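This account rests on a few compounds, and the source may have more. Where it says the series, first, only, none or still open, it means among the compounds named here.

Of the compounds shown here, two have so far been measured in an assay on CHO cells for displacement of a labelled ligand from adenosine receptor A1 (Homo sapiens), read by scintillation counting, with a stated time of 90 min; a lower number here means a stronger inhibitor, a higher number a weaker inhibitor. Compound 1 `CCn1nc(-c2ccccc2)c2sccc2c1=O` gives 2670 nM. Compound 2 `CCn1nc(-c2ccccn2)c2sccc2c1=O` gives 782 nM. Going by the values given here, the only measured step, a 3.4-fold lower number from compound 1 to compound 2 (0.53 log units; beyond the scatter), concerns the aryl group on the core and leaves the chain on the ring nitrogen untouched. Among the compounds with values here, compound 2 stands lowest of the two numbers; compound 1 is its only neighbour. Compound 3 `CC(C)n1nc(-c2ccccn2)c2sccc2c1=O` differs from compound 2 by methyl in place of hydrogen on a saturated chain carbon bound to an aromatic nitrogen and a saturated chain carbon. Within the data shown here, no measured step bears on this change: the step from compound 1 to compound 2 is at a different part of the structure and gives no guide to direction or size here. The working expectation for compound 3 is a step within the scatter, a 1.0-fold higher number from compound 2 to compound 3 (0.01 log units; within the scatter), without a favoured direction. The estimate for compound 3 in this assay is 800 nM, with a range from 250 nM to 2500 nM.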

Compound 3, inhibition constant: 912 nM
Compound 3: middle estimate off by 1.1-fold (0.06 log units), on the low side; measured number inside the range.
By their numbers in this assay, from the lowest: compounds 2 and 3 (each within the scatter of the next); then compound 1.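

Going by these compounds alone, on the saturated chain carbon bound to an aromatic nitrogen and a saturated chain carbon, ethyl to isopropyl in this assay gives a 1.2-fold higher number from compound 2 to compound 3 (0.07 log units; within the scatter), the first measured step at this position; the earlier step concerned only the aryl group on the core. With pyridin-2-yl held in place, the added methyl brings no difference beyond the scatter, so this one branch is tolerated in this assay. Nothing measured on the compounds speaks to why the step is this small.

Open, going by these compounds, is whether a longer chain, a cyclopropyl ring, or a chain ending in an amine or a carboxylic acid at this position would also stay within the scatter. Also open, on these data alone, is whether ethyl to isopropyl reads the same with phenyl in place of pyridin-2-yl.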